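Amino-to-alkoxy swap at the pyridine in the urea series

This account rests on a few compounds, and the source may have more. Where it says the series, first, only, none or still open, it means among the compounds named here.

The series shares one core; compound 1 `O=C(NCc1ccc(C(F)(F)F)nc1N1CCCCC1)Nc1cccc2c(=O)[nH]ccc12` carries piperidin-1-yl on the ring, compound 2 `O=C(NCc1ccc(C(F)(F)F)nc1N1CCCC1)Nc1cccc2c(=O)[nH]ccc12` pyrrolidin-1-yl, and compound 3 `CCCN(CCC)c1nc(C(F)(F)F)ccc1CNC(=O)Nc1cccc2c(=O)[nH]ccc12` dipropylamino. In an assay on CHO cells for agonist activity at transient receptor potential cation channel subfamily V member 1 (Homo sapiens) (a lower number here means that less compound is needed, a higher number that more compound is needed for the effect), compound 1 gives 13.2 nM, compound 2 gives 258 nM, and compound 3 gives 2.79 nM. Compound 3 stands lowest of the three: the step of a 4.7-fold lower number from compound 1 to compound 3 (0.67 log units; beyond the scatter) is modest, whereas a 92-fold lower number from compound 2 to compound 3 (1.97 log units; beyond the scatter) is large, and the contraction a 20-fold higher number from compound 1 to compound 2 (1.29 log units; beyond the scatter) is itself large.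

Compound 4 `CC(C)COc1nc(C(F)(F)F)ccc1CNC(=O)Nc1cccc2c(=O)[nH]ccc12` is the next variation at the same position: isobutoxy in place of dipropylamino on an aromatic carbon. Both steps measured at this position concern nitrogen-linked groups only, so the effect of an oxygen-linked group is not covered by any measured step. The trend among the three measured groups runs from the larger, open dipropylamino at the low end to the small pyrrolidin-1-yl ring at the high end; isobutoxy is smaller than dipropylamino and changes the linking atom, so a rise in this assay is expected, likely of modest to large size, with the direction more certain than its magnitude.

On this basis compound 4 is expected to give about 40 nM in this assay, with a range of 8 nM to 250 nM. The estimated step is therefore a 14-fold higher number from compound 3 to compound 4 (1.16 log units; beyond the scatter).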

Compound 4, half-maximal effective concentration: 78.7 nM
Estimate against measurement, compound 4: 2.0-fold (0.29 log units) below; the range from low to high includes it.
By their numbers in this assay, from the lowest: compound 3; then compound 1; then compound 4; then compound 2.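

Isobutoxy is the first oxygen-linked group shown on this aromatic carbon next to the ring nitrogen, and in this assay it does not keep the low number of the other open-chain group: a 28-fold higher number from compound 3 to compound 4 (1.45 log units; beyond the scatter) is large, so having no ring does not by itself give a low number in this small set. Against the two ring amines it falls in the middle, with a 6.0-fold higher number from compound 1 to compound 4 (0.78 log units; beyond the scatter) and a 3.3-fold lower number from compound 2 to compound 4 (0.52 log units; beyond the scatter) both modest, so the oxygen-linked group stays inside the span already set by the nitrogen-linked groups. No measurement at hand offers an explanation for these differences.

The swap from dipropylamino to isobutoxy changes the linking atom and the heavy-atom count together, and the compounds shown do not separate the two contributions; an isobutylamino group would hold the chain and change only the linking atom. Also open, from the compounds shown here alone, is whether a longer ether such as hexyloxy, or a sulfur-linked isobutylthio group, would move the number towards that of compound 3.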